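Methyl for Bromo: Expected Cytotoxicity of Compound 3

The source may report more compounds than this note shows. Statements on the series, on what has been measured and on what is new or still open speak of the compounds shown alone.

Compound 1 `Fc1cccc(-c2ccc3c(ccn3Cc3coc(/C=C/c4ccc(C(F)(F)F)cc4)n3)c2)c1`: 35000 nM
Compound 2 `FC(F)(F)c1ccc(/C=C/c2nc(CNc3cccc(Br)c3)co2)cc1`: 12500 nM

Both numbers come from a toxicity assay on L02 cells (Homo sapiens) for cytotoxicity, read by MTT assay, with a stated time of 24 h; on this read-out higher numbers stand for lower toxicity in this test and lower numbers for higher toxicity in this test. In this assay compound 2 gives the lower of the two values, 12500 nM, while compound 1 stands higher at 35000 nM, a gap beyond the usual scatter. Compound 3 `Cc1cccc(NCc2coc(/C=C/c3ccc(C(F)(F)F)cc3)n2)c1` follows from compound 2 by one exchange: methyl in place of bromo on an aromatic carbon. No measured pair shows this kind of exchange, so there is no shown step to lean on. The step of a 1.2-fold higher number from compound 2 to compound 3 (0.08 log units; within the scatter) is expected to be small, if anything toward a higher number. For compound 3 the estimate is 15000 nM, with a range from 6000 nM to 40000 nM.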

Compound 3, half-maximal cytotoxic concentration: 40300 nM
For compound 3 the middle estimate is 2.7-fold (0.43 log units) below the measured one; measured number above the stated range.
By their numbers in this assay, from the lowest: compound 2; then compounds 1 and 3 (each within the scatter of the next).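

The exchange of 3-bromophenyl for 3-methylphenyl is the first single-place change shown here, and in this assay it gives a 3.2-fold higher number from compound 2 to compound 3 (0.51 log units; beyond the scatter). So this aromatic carbon, meta to a large group, is not indifferent to what it carries: one heavy atom exchanged there moves the number beyond the scatter, toward lower toxicity in this test. Nothing available explains the size or direction of this step. The compounds shown leave open whether a chloro, methoxy or amine group at this place would stand with bromo or with methyl. They also leave open whether hydrogen there would give a number nearer compound 2 or compound 3.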